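This account rests on a few compounds, and the source may have more. Where it says the series, first, only, none or still open, it means among the compounds named here.

Compound 1 `O=C(c1ccc(Cl)cc1)c1ccn(-c2ccc3c(c2)B(O)OC3)c1` gives in an ADME assay on L929 cells (Mus musculus) for cytotoxicity, read by resazurin assay, with a stated time of 72 h (on this read-out higher numbers stand for weaker inhibition and lower numbers for stronger inhibition), only the limit > 10 ug/mL.
Compound 2 `COc1ccc(C(=O)c2ccn(-c3ccc4c(c3)B(O)OC4)c2)cc1` gives in this assay only the limit > 10 ug/mL.
Compound 3 `CC(=O)OCc1ccc(C(=O)c2ccn(-c3ccc4c(c3)B(O)OC4)c2)cc1` gives in this assay the number 10 ug/mL.

Compound 2 therefore stands at the limit of > 10 ug/mL in this assay, at which 2 of the 3 values shown sit. Compound 4 `Cc1ccsc1C(=O)c1ccn(-c2ccc3c(c2)B(O)OC3)c1` differs from it by 3-methylthiophen-2-yl in place of 4-methoxyphenyl on a carbonyl carbon. The measured steps, a step that the two limits leave unreadable from compound 1 to compound 2 and a number no higher from compound 2 to compound 3 (the limit leaves the size open), all exchange one group on an aromatic carbon of the ring that stays, whereas this change replaces the ring itself, so none of them speaks to it directly, and their sizes are in any case not readable. No direction can be drawn from them, and the step that the limit leaves unreadable from compound 2 to compound 4 is expected to stay within the scatter. Compound 4 is estimated at 12 ug/mL, between 5 ug/mL and 30 ug/mL.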

Compound 4, half-maximal inhibitory concentration: > 10 ug/mL
Compound 4: only a limit was reported; the forecaster's own chance of this, stated with the estimate: 60%; the middle value is on the limit's open side.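

Compound 4, like compound 1 and compound 2, gives only a limit, so neither step to compound 4 can be read: the limit of > 10 ug/mL in this assay, at which 3 of the 4 values shown sit.

The compounds shown leave open how far these three actually lie apart in this assay.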